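From naphthalen-1-yl to naphthalen-2-yl on the carbonyl carbon

The compounds below may be only part of what the source reports. "The series", "measured", "known", "first", "only" and "open" are said of these compounds alone.

Going by the values given here, in an ADME assay on MT4 cells (Homo sapiens) for cytotoxicity, read by MTT assay (a higher number here means that more compound is tolerated, a lower number that less compound is tolerated), compound 1 `COc1cccc(OC)c1C(=O)N(C(=S)OCCN1C(=O)c2ccccc2C1=O)c1ccc(Cl)cc1` gives 69000 nM and compound 2 `O=C1c2ccccc2C(=O)N1CCOC(=S)N(C(=O)c1cccc2ccccc12)c1ccc(Cl)cc1` gives 6000 nM as the lower of the two numbers so far. Compound 3 `O=C1c2ccccc2C(=O)N1CCOC(=S)N(C(=O)c1ccc2ccccc2c1)c1ccc(Cl)cc1` is not yet measured and carries naphthalen-2-yl in place of naphthalen-1-yl on a carbonyl carbon with the same atoms joined differently. Among the compounds with values here, the only measured step at this place runs a 12-fold lower number from compound 1 to compound 2 (1.06 log units; beyond the scatter) and is large, but it exchanges 2,6-dimethoxyphenyl for naphthalen-1-yl. Within the data shown here, no measured pair compares the two naphthalenyl groups, so that step sets no size for this change. No step beyond the scatter is expected in this assay and the number may be slightly higher. The estimated step runs a 1.3-fold higher number from compound 2 to compound 3 (0.12 log units; within the scatter) as a working expectation. Among the measured compounds shown here, compound 3 is expected at 8000 nM with an estimated range from 2500 nM to 25000 nM given the single step available.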

Compound 3, half-maximal cytotoxic concentration: 37000 nM
Beside the measured number, compound 3's estimate is 4.6-fold (0.67 log units) below it; the measured number lies above the stated range.
By their numbers in this assay, from the lowest: compound 2; then compounds 3 and 1 (each within the scatter of the next).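

Where the naphthalene joins the carbonyl carbon matters in this assay: with the same atoms joined differently, naphthalen-2-yl in place of naphthalen-1-yl gives a 6.2-fold higher number from compound 2 to compound 3 (0.79 log units; beyond the scatter), so the two isomers cannot be treated as one naphthalenyl group at this position. Going by these compounds alone, the earlier large step therefore does not follow from a naphthalene as such, since the change from 2,6-dimethoxyphenyl to naphthalen-2-yl gives only a 1.9-fold lower number from compound 1 to compound 3 (0.27 log units; within the scatter) and leaves naphthalen-1-yl as the one group of the three with a clearly lower number. Nothing on hand explains why the two isomers differ.

From the compounds shown here alone, whether a plain phenyl or a cyclohexyl on the carbonyl carbon would fall with naphthalen-1-yl or with the other two groups stays open. Also open, going by these compounds, is whether the gap between the isomers persists when another part of the shared core changes.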